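The source may hold more compounds than are shown below. What is called first, only, known or untested is meant among the compounds shown, and "the series" means these compounds.

Compound 1 `O=C(CSc1nc(Nc2ccccc2)c2ccccc2n1)Nc1cccc(Cl)c1` and compound 2 `O=C(CSc1nc(Nc2ccccc2)c2ccccc2n1)Nc1cccc(Br)c1` share one core, and in a functional assay on NCI-H1975 cells (Homo sapiens) for inhibition, read by MTT assay, with a stated time of 72 h (a lower number here means a stronger inhibitor, a higher number a weaker inhibitor), compound 1 gives 8460 nM while compound 2 gives 10100 nM. The change between them, (bromo in place of chloro on an aromatic carbon), produced a 1.2-fold higher number from compound 1 to compound 2 (0.08 log units; within the scatter). Compound 3 `C=CC(=O)Nc1cccc(NC(=O)CSc2nc(Nc3ccccc3Cl)c3ccccc3n2)c1` carries a different core; how it differs from compound 1 is not broken down here. In this assay compound 3 gives 10000 nM, and its value sits within the scatter of both compound 1 and compound 2.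

Compound 4 `C=CC(=O)Nc1cccc(NC(=O)CSc2nc(Nc3ccccc3Br)c3ccccc3n2)c1` is not yet measured. It differs from compound 3 by bromo in place of chloro on an aromatic carbon. Within the data shown here, this is the same kind of change as the one from compound 1 to compound 2, but not the same: there the halogen sat meta to a large group, here it sits ortho to a large group, and the two cores differ. Because the earlier change gave a 1.2-fold higher number from compound 1 to compound 2 (0.08 log units; within the scatter), a step of similar size is expected here, a 1.1-fold higher number from compound 3 to compound 4 (0.04 log units; within the scatter). Compound 4 is therefore estimated to give about 11000 nM in this assay, with a likely range from 5000 nM to 25000 nM.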

Compound 4, half-maximal inhibitory concentration: 19300 nM
Compound 4: the middle estimate sits 1.8-fold (0.24 log units) below what was measured; measured number inside the range.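

In this assay, putting bromo in place of chloro on an aromatic carbon, ortho to a large group, produced a 1.9-fold higher number from compound 3 to compound 4 (0.29 log units; within the scatter), and the same kind of change on the other core produced a 1.2-fold higher number from compound 1 to compound 2 (0.08 log units; within the scatter). Set side by side, the two steps do not differ beyond what repeated measurements would allow: the same change on two cores in this assay, a 1.2-fold higher number (0.08 log units; within the scatter) from compound 1 to compound 2 and a 1.9-fold higher number (0.29 log units; within the scatter) from compound 3 to compound 4, 1.6-fold (0.21 log units) apart, within the scatter of two such steps. Among these compounds, this shows that the swap can be carried between these two cores without a detectable difference in its size, but with each step within the scatter and only two pairs available, it does not show that the swap has any real effect on either core, or that the two cores respond identically.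

The compounds shown leave open how fluoro, iodo, a methoxy group or an amine would read in place of the halogen on the 2-chlorophenyl ring. They also leave open whether the parallel between the two steps would hold on any further core in this series.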